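The source may hold more compounds than are shown below. What is called first, only, known or untested is meant among the compounds shown, and "the series" means these compounds.

Measured so far in a functional assay on L1210 cells (Mus musculus) for cytotoxicity; on this read-out lower numbers stand for an effect already at smaller amounts and higher numbers for an effect only at larger amounts of compound:

compound 1, `CCCC(O)C1=CC(=O)c2c(OC)ccc(OC)c2C1=O`, 0.409 ug/mL
compound 2, `COc1cc(C(C)O)c(OC)c2c1C(=O)C=CC2=O`, 0.132 ug/mL
compound 3, `CCCCC(O)C1=CC(=O)c2c(OC)ccc(OC)c2C1=O`, 0.412 ug/mL

Of these three, compound 2 stands lowest in this assay, and both compound 1 and compound 3 lie above it by more than the usual scatter. Compound 1 and compound 3 are built on one core and carry a hydroxyalkyl chain on a double-bonded ring carbon; compound 2 is built on a core with the methoxy groups in a different arrangement and carries its 1-hydroxyethyl group on an aromatic carbon.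

The step under consideration leads from compound 2 to compound 4, `CCCCCCC(O)c1cc(OC)c2c(c1OC)C(=O)C=CC2=O`. The change is pentyl in place of hydrogen on a saturated chain carbon, two bonds along the chain from an aromatic carbon and an oxygen on a saturated carbon, so that the 1-hydroxyethyl group becomes a 1-hydroxyheptyl group.

Going by the values given here, only one measured step speaks to lengthening such a chain: a 1.0-fold higher number from compound 1 to compound 3 (0.00 log units; within the scatter). That step adds a single carbon, whereas here five carbons enter, and it sits on the other core, so the evidence is thin. With nothing pointing to a shift, the step is expected to be a 1.4-fold higher number from compound 2 to compound 4 (0.13 log units; within the scatter), that is no change beyond the scatter, with the wider uncertainty of a larger change. Compound 4 is therefore estimated at 0.18 ug/mL in this assay, with a range from 0.06 ug/mL to 0.55 ug/mL.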

Compound 4, concentration for half-maximal effect: 0.22 ug/mL
For compound 4 the middle estimate is 1.2-fold (0.09 log units) below the measured one; the range from low to high includes it.
By their numbers in this assay, from the lowest: compounds 2, 4, 1 and 3 (each within the scatter of the next, the first and the last beyond it).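

In this assay, the core of compound 2 accepts a pentyl in place of hydrogen on a saturated chain carbon, two bonds along the chain from an aromatic carbon and an oxygen on a saturated carbon, with a 1.7-fold higher number from compound 2 to compound 4 (0.22 log units; within the scatter). Until now, the only view of chain length came from a single added carbon on the other core, with a 1.0-fold higher number from compound 1 to compound 3 (0.00 log units; within the scatter); this result shows that, on the core of compound 2, turning 1-hydroxyethyl into 1-hydroxyheptyl also leaves the read-out within the scatter, even though five carbons enter at once. No measurement shown here offers an explanation for this result.

The compounds shown leave open whether a longer chain than the hexyl of compound 4, or a chain ending in an amine or a carboxylic acid, would also leave the number in the same place. They also leave open how a 1-hydroxyheptyl group would behave on the core of compound 1, where the chains shown stop at a shorter length.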